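A few compounds are considered here, and "the series" means these few. Any claim that something is new, unique, unknown or untested is made for them only; others in the source may bear on it.

Measured compounds:
Compound 1, `COc1ccc(CS(=O)(=O)/C=C/c2ccc(F)cc2OC)cc1`, gives 10000 nM in a functional assay on DU-145 cells (Homo sapiens) for antiproliferative activity, read by trypan blue exclusion; a lower number here means a stronger inhibitor, a higher number a weaker inhibitor.
Compound 2, `COc1ccc(CS(=O)(=O)/C=C/c2ccc(OC)cc2OC)cc1`, gives > 20000 nM in this assay. That reading is a limit of the assay, not a number.

Going by these compounds, compound 2 thus stands at the edge of what this assay can report (the limit of > 20000 nM in this assay, at which 1 of the 2 values shown sits); how far beyond that bound it lies is unknown. Compound 3, `COc1ccc(CS(=O)(=O)/C=C/c2cc(OC)c(OC)cc2OC)cc1`, differs from compound 2 in one place: methoxy in place of hydrogen on an aromatic carbon.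

Among the measured compounds shown here, only one measured step bears on this change: an at least 2.0-fold higher number from compound 1 to compound 2 (0.30 log units; that floor lies within the scatter). That step also brought a methoxy group onto the same ring, though in place of fluoro rather than hydrogen, and it pushed the number up to the limit, with a floor that still sits within the scatter. For the measured compounds named here, nothing among the measured compounds suggests that a further methoxy group should pull the number back down. The expected step is therefore a step that the limit leaves unreadable from compound 2 to compound 3, no change beyond the scatter, with a limit as the most likely outcome. Compound 3 is estimated at 25000 nM, in a range from 8000 nM to 60000 nM.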

Compound 3, half-maximal inhibitory concentration: > 20000 nM
Compound 3: only a limit was reported (the forecaster's own chance of this, stated with the estimate: 75%); the middle value lies beyond the limit too.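

Compound 3 gives > 20000 nM in this assay, which is a limit of the assay and not a number. Compound 2 also stands at a limit, so no step from compound 2 to compound 3 can be read: the limit of > 20000 nM in this assay, at which 2 of the 3 values shown sit.

Going by these compounds, how far each compound lies past that limit stays open, and so does whether the added methoxy group changes the reading at all.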